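Ring stereocentre inversion in a cytotoxicity series

The source may report more compounds than this note shows. Statements on the series, on what has been measured and on what is new or still open speak of the compounds shown alone.

Compound 1 `C=C(C)[C@@H]1C[C@@H](CC2(CC=C(C)C)C(=O)C(C(CC(=O)O)c3ccccc3)=C3O[C@H](C)[C@@H](C)C(=O)C3=C2O)C1(C)C`, compound 2 `C=C(C)[C@@H]1C[C@@H](CC2(CC=C(C)C)C(=O)C(C(CC(=O)O)c3ccccc3)=C3O[C@@H](C)[C@@H](C)C(=O)C3=C2O)C1(C)C` and compound 3 `C=C(C)CCC1(C=C(C)C)C(=O)C2=C(O)[C@H](C)[C@@H](C)OC2=C(C(CC(=O)O)c2ccccc2)C1=O` share the same core and differ in the unsaturated chains and in ring stereochemistry. In a functional assay on KB cells (Homo sapiens) for cytotoxicity (a higher number here means a weaker inhibitor, a lower number a stronger inhibitor), compound 1 gives only a limit, > 20 ug/mL. In this assay compound 2 likewise gives only a limit, > 20 ug/mL. Compound 3 also returns only a limit in this assay, > 20 ug/mL. The change from compound 1 to compound 2 is a stereocentre at a saturated ring carbon drawn R in one and S in the other, and the step that the two limits leave unreadable from compound 1 to compound 2 cannot be read, because the limit of > 20 ug/mL in this assay, at which 3 of the 3 values shown sit, and because of the fact that one of compounds 1 and 2 is drawn with a defined configuration and the other without, at the place where they differ. Compound 3 thus stands where every other value shown stands, at a limit, with no number known for it.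

Compound 4 `C=C(C)CCC1(C=C(C)C)C(=O)C2=C(O)[C@H](C)[C@H](C)OC2=C(C(CC(=O)O)c2ccccc2)C1=O` is the next member. Relative to compound 3 the difference is the two compounds have the same atoms and bonds; at least one stereo element is drawn with a configuration in one of them and without one in the other: 1 of 4 stereo elements differ; a stereocentre at a saturated ring carbon is drawn R in compound 3 and S in compound 4. Within the data shown here, the only measured step that bears on this kind of change is the one from compound 1 to compound 2, and that step is unreadable between two limits. Nothing shown points to a step beyond the scatter in either direction. The expected step that the limit leaves unreadable from compound 3 to compound 4 is accordingly nil. Compound 4 is estimated at 40 ug/mL, with a range from 15 ug/mL to 120 ug/mL, and a limit is the most likely report.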

Compound 4, half-maximal inhibitory concentration: > 20 ug/mL
Compound 4: no number, only a limit; the forecaster's own chance of this, stated with the estimate: 85%; the middle value does not contradict the limit.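

In this assay compound 4 gives only a limit (> 20 ug/mL). No step can be read between compound 3 and compound 4, because neither has a number: the limit of > 20 ug/mL in this assay, at which 4 of the 4 values shown sit. The compounds shown leave open whether the R or S configuration at this ring stereocentre affects cytotoxicity, and how far any of the four compounds lies from the limit.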